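A Swap on the Side Chain of Compound 1

The source may report more compounds than this note shows. Statements on the series, on what has been measured and on what is new or still open speak of the compounds shown alone.

Compound 1 `N#CNC(=N)NCCCn1nc(-c2ccccc2)ccc1=O` carries a flexible chain that ends in a nitrogen-rich group. In a functional assay on the whole organism (stomach) with Rattus norvegicus as the target (on this read-out higher numbers stand for an effect only at larger amounts of compound and lower numbers for an effect already at smaller amounts), compound 1 gives > 100 mg/kg, which is a limit of the assay rather than a number. Two related compounds tell the same story. Compound 2 `O=c1ccc(-c2ccccc2)nn1CCCCNC(=S)Nc1ccc(Cl)cc1` gives > 100 mg/kg in this assay, again only a limit. Compound 3 `C/N=C(/NC#N)NCCCCn1nc(-c2ccccc2)c(C)cc1=O` gives > 100 mg/kg in this assay, also a limit. So compound 1 stands exactly where every measured value stands: at the limit of > 100 mg/kg in this assay, at which 3 of the 3 values shown sit.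

Compound 4 `CC/N=C(\S)NCCCCn1nc(-c2ccccc2)ccc1=O` differs from compound 1 by a single change: a group of 7 heavy atoms (4 carbon, 2 nitrogen, 1 sulfur; no ring) in place of a group of 6 heavy atoms (2 carbon, 4 nitrogen; no ring), on a saturated chain carbon, three bonds along the chain from an aromatic nitrogen. Within the data shown here, no measured pair shows what such a change does in this assay, so there is no step to lean on. With every known value sitting at the limit, no movement beyond the usual scatter is expected. Compound 4 is therefore expected to give 100 mg/kg, within 30 mg/kg to 300 mg/kg, in this assay. That corresponds to an expected step of a number no higher from compound 1 to compound 4 (the limit leaves the size open), most likely another value that the assay reports only as a limit.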

Compound 4, dose for half-maximal effect: 37.2 mg/kg
Estimate against measurement, compound 4: 2.7-fold (0.43 log units) above; low and high end bracket the measured number.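

Until this result, the compounds offered only a ceiling and no real number to compare: the limit of > 100 mg/kg in this assay, at which 3 of the 4 values shown sit.

Compound 4 is the one compound shown that comes off that limit, and in this assay the swap on the side chain amounts to an at least 2.6-fold lower number from compound 1 to compound 4 (0.42 log units; beyond the scatter). This place on the chain is therefore not silent: what sits there can shift the read-out to a true number, and a group holding sulfur and no triple bond is one that does so.

The swap alters several features at once, so the compounds shown cannot say whether the sulfur, the added carbon atoms or the lost triple bond carries the step. They also leave open how a simple amine, a carboxylic acid or a longer chain would fare at this place.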